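Compound 4: cyclohexyl in place of 3-fluorophenyl

This account rests on a few compounds, and the source may have more. Where it says the series, first, only, none or still open, it means among the compounds named here.

Within the data shown here, compound 1 `Cc1cc(C(=O)O)ccc1CN1CCC[C@H](O[C@H](CO)c2cc(Cl)cc(Cl)c2)[C@@H]1c1cccc(F)c1` stands second highest of the three numbers so far in an assay on isolated protein for activation of cGMP-dependent protein kinase 1 (Homo sapiens), read by ADP-Glo, with stated times of 30 min and 2 h, in the presence of a further agent that is not named here (a lower number here means that less compound is needed, a higher number that more compound is needed for the effect), where compound 1 gives 12000 nM. Compound 2 `Cc1cc(C(=O)O)ccc1CN1CCC[C@H](O[C@H](CO)c2ccccc2)[C@@H]1c1ccccc1` gives 25000 nM, and compound 3 `Cc1cc(C(=O)O)ccc1CN1CCC[C@H](O[C@H](CO)c2cc(Cl)nc(Cl)c2)[C@@H]1c1ccccc1` gives 2400 nM. Among the measured compounds shown here, the one measured step, a 10-fold lower number from compound 2 to compound 3 (1.02 log units; beyond the scatter), changes the group on the saturated chain carbon. Compound 4 `Cc1cc(C(=O)O)ccc1CN1CCC[C@H](O[C@H](CO)c2cc(Cl)cc(Cl)c2)[C@@H]1C1CCCCC1` differs from compound 1 at another place: cyclohexyl in place of 3-fluorophenyl on a saturated ring carbon. For the measured compounds named here, no measured step touches that ring carbon, so the step from compound 2 to compound 3 offers no direct guide, and the expected step in this assay is none beyond the scatter, with a wide range. The estimate for compound 4 in this assay is 12000 nM, between 3500 nM and 40000 nM, meaning an expected step of no change at the digits printed from compound 1 to compound 4 (within the scatter).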

Compound 4, half-maximal effective concentration: 65000 nM
Compound 4: middle estimate off by 5.4-fold (0.73 log units), on the low side; the whole stated range lies below it.
By their numbers in this assay, from the lowest: compound 3; then compound 1; then compound 2; then compound 4.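

Among these compounds, the saturated ring carbon next to the ring nitrogen also affects the number in this assay, a place that no earlier step touched: cyclohexyl in place of 3-fluorophenyl gives a 5.4-fold higher number from compound 1 to compound 4 (0.73 log units; beyond the scatter). The change removes both the aromatic ring and the fluorine, and this single pair cannot separate the two. No measurement given here bears on why the number rises. From the compounds shown here alone, whether plain phenyl would keep the number of compound 1 remains open with the dichlorophenyl group in place. So does the outcome with a methyl group or a pyridin-3-yl ring on this carbon.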